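The source may hold more compounds than are shown below. What is called first, only, known or untested is meant among the compounds shown, and "the series" means these compounds.

Working notes on the series. The shared core is that of compound 1 `COc1ccc(-c2nc(N3CCNCC3)nc3ccccc23)c(OC)c1`. In a functional assay on C-33-A cells (Homo sapiens) for antiproliferative activity, read by MTT assay (on this read-out lower numbers stand for stronger inhibition and higher numbers for weaker inhibition), compound 1 gives 50 ug/mL. Compound 2 `c1ccc2c(c1)ccn2-c1nc(N2CCCCC2)nc2ccccc12` gives 50 ug/mL, and compound 3 `Cn1cc(-c2nc(N3CCNCC3)nc3ccccc23)c2ccccc21` gives 50 ug/mL. Compound 1 therefore stands level with both, each gap within the scatter, so no order among the three is drawn. Compound 4 `COc1cc(OC)c(-c2nc(N3CCNCC3)nc3ccccc23)c(OC)c1` differs from compound 1 by methoxy in place of hydrogen on an aromatic carbon. Among the measured compounds shown here, no step between measured compounds is on hand to show what such a change does, and the three measured values sit at one point, so no direction is indicated. In this assay the expected step is no change at the digits printed from compound 1 to compound 4 (within the scatter), within the scatter. Compound 4 is accordingly estimated at 50 ug/mL, with a range from 20 ug/mL to 100 ug/mL.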

Compound 4, half-maximal inhibitory concentration: 50 ug/mL
Estimate against measurement, compound 4: no gap at the digits printed; the range from low to high includes it.
By their numbers in this assay, from the lowest: compounds 1, 2, 3 and 4 (each within the scatter of the next).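

In this assay the step for methoxy in place of hydrogen on an aromatic carbon, ortho to a large group and meta to two methoxy groups, reads no change at the digits printed from compound 1 to compound 4 (within the scatter), the first step available in the series. This position therefore takes a methoxy group without a shift beyond the scatter. Nothing on hand bears on a cause for this result.

From the compounds shown here alone, whether an amine or a carboxylic acid on this same aromatic carbon would move the value remains open. So does the effect of a longer chain, such as butoxy, at this position.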